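The source may hold more compounds than are shown below. What is called first, only, known or untested is meant among the compounds shown, and "the series" means these compounds.

Of the compounds shown here, three sharing a common design have been tested in a functional assay on A549 cells (Homo sapiens) for antiproliferative activity, read by MTT assay, with a stated time of 72 h (on this read-out higher numbers stand for weaker inhibition and lower numbers for stronger inhibition), and a fourth awaits its turn.

Compound 1, `C=C(C)C(=O)Nc1cc2c(N3CCc4ccccc43)ncnc2cc1OC`, gives 7320 nM in this assay. Compound 2, `C=C(C)C(=O)Nc1cc2c(N3CCc4ccccc43)ncnc2cc1O[C@@H]1CCOC1`, is built from compound 1 by a single change, (oxolan-3-yl in place of methyl on an oxygen on an aromatic ring), and in this assay compound 2 gives 16600 nM. The step of a 2.3-fold higher number from compound 1 to compound 2 (0.36 log units; beyond the scatter) is therefore a weakening, modest in size but larger than what repeated measurements usually scatter over.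

Compound 3, `COc1cc2ncnc(N3CCCc4ccccc43)c2cc1NC(=O)C=C(C)C`, rests on a different core; how its core differs from that of compound 1 is not broken down here. In this assay compound 3 gives 5410 nM, which lies within the scatter of the number for compound 1, so the two cannot be ranked against each other, while compound 2 sits clearly higher than both.

Compound 4, `CC(C)=CC(=O)Nc1cc2c(N3CCCc4ccccc43)ncnc2cc1O[C@@H]1CCOC1`, is to compound 3 what compound 2 is to compound 1: the change (oxolan-3-yl in place of methyl on an oxygen on an aromatic ring), made at a place described in exactly the same words. It is the same change, seen a second time on another core.

The expectation for compound 4 rests on that single precedent. Among the measured compounds shown here, the step of a 2.3-fold higher number from compound 1 to compound 2 (0.36 log units; beyond the scatter) is the only guide to how this change behaves, so the step from compound 3 to compound 4 is estimated at about the same size, a 2.2-fold higher number from compound 3 to compound 4 (0.35 log units; beyond the scatter). On that basis compound 4 is expected to give roughly 12000 nM in this assay, most likely between 6000 nM and 25000 nM. Whether the second core carries the change the same way is exactly what the coming measurement will show.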

Compound 4, half-maximal inhibitory concentration: 7910 nM
For compound 4 the middle estimate is 1.5-fold (0.18 log units) above the measured one; low and high end bracket the measured number.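

In this assay, among the compounds shown here, replacing methyl with oxolan-3-yl on the oxygen of the second core gives a 1.5-fold higher number from compound 3 to compound 4 (0.16 log units; within the scatter) and so leaves compound 3 and compound 4 indistinguishable, whereas the same change on the first core gave a step that could be read as a real weakening. Although one step falls within the scatter and the other beyond it, the two steps themselves cannot be told apart: the same change on two cores in this assay, a 2.3-fold higher number (0.36 log units; beyond the scatter) from compound 1 to compound 2 and a 1.5-fold higher number (0.16 log units; within the scatter) from compound 3 to compound 4, 1.6-fold (0.19 log units) apart, within the scatter of two such steps. This shows that the change behaved compatibly on both cores and that neither pair offers evidence of a gain in antiproliferative activity, but it does not show that the change has an identical effect on both, and two pairs are too few to support a rule for any further core in this series.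

The compounds shown carry only methyl and one mirror-image form of oxolan-3-yl on this oxygen, so it remains open how the other form, a longer chain such as 2-methoxyethyl, or a chain ending in an amine would behave. It also remains open which of the structural differences between the two cores matters here, since no pair shown isolates any one of them.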